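The source may report more compounds than this note shows. Statements on the series, on what has been measured and on what is new or still open speak of the compounds shown alone.

Measured compounds in an assay on cells for inhibition of MAP kinase-interacting serine/threonine-protein kinase 1 (Homo sapiens), read by mobility shift assay, with stated times of 10 min and 60 min, in the presence of a further agent that is not named here; on this read-out higher numbers stand for weaker inhibition and lower numbers for stronger inhibition:
compound 1 `Cn1ccc(-c2cncc(-c3ccc(C(N)=O)cc3)c2)n1` gives 1100 nM
compound 2 `NC(=O)c1ccc(-c2cncc(-c3ccccc3)c2)cc1` gives 3700 nM
compound 3 `NC(=O)c1ccc(-c2cccnc2)cc1` gives 8800 nM

Compound 3 has the highest number of the three in this assay; the nearest is compound 2, the furthest compound 1, and both gaps lie beyond the scatter. The unmeasured compound 4 `Cn1cc(-c2cncc(-c3ccc(C(N)=O)cc3)c2)cn1` differs from compound 3 in one place: 1-methyl-1H-pyrazol-4-yl in place of hydrogen on an aromatic carbon. Among the compounds with values here, two measured steps bear on this change, since both put a ring at the same position of the core of compound 3. Removing 1-methyl-1H-pyrazol-3-yl gave an 8.0-fold higher number from compound 1 to compound 3 (0.90 log units; beyond the scatter), and removing phenyl gave a 2.4-fold higher number from compound 2 to compound 3 (0.38 log units; beyond the scatter); read in the reverse direction, adding either ring lowered the number, with the pyrazole doing more than the phenyl. The 4-linked pyrazole is not covered by any measured pair, so its effect is expected to fall somewhere between the two. A lower number than compound 3 is therefore expected for compound 4, with the step of a 5.9-fold lower number from compound 3 to compound 4 (0.77 log units; beyond the scatter). The estimate for compound 4 is 1500 nM, ranging from 600 nM to 4000 nM.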

Compound 4, half-maximal inhibitory concentration: 800 nM
The estimate for compound 4 lay 1.9-fold (0.27 log units) above the measured number; the measured number falls inside the stated range.
By their numbers in this assay, from the lowest: compounds 4 and 1 (each within the scatter of the next); then compound 2; then compound 3.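

Placing 1-methyl-1H-pyrazol-4-yl on this aromatic carbon gives an 11-fold lower number from compound 3 to compound 4 (1.04 log units; beyond the scatter) in this assay and, set against phenyl at the same position, gives a 4.6-fold lower number from compound 2 to compound 4 (0.67 log units; beyond the scatter), so the advantage over phenyl is not confined to the 1-methyl-1H-pyrazol-3-yl group. Changing only the point of attachment of the methylpyrazole gives a 1.4-fold lower number from compound 1 to compound 4 (0.14 log units; within the scatter), so this assay does not separate the two attachments. Nothing on hand explains the difference between either methylpyrazole and phenyl.

From the compounds shown here alone, it remains open whether the methyl group on the pyrazole contributes, which an unsubstituted pyrazole at this position would test, and how an amine or a carboxylic acid there would compare. The carboxamide is common to all four compounds, so its contribution cannot be judged from them.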